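The compounds below may be only part of what the source reports. "The series", "measured", "known", "first", "only" and "open" are said of these compounds alone.

Measured compounds:
compound 1 `CCC(=O)c1ccc(OCCCCOc2ccc(F)c(C(=O)O)c2)c(C)c1O`: 35%
compound 2 `Cc1ccc(C(=O)O)cc1OCCCCOc1ccc(C(=O)CC2CCCC2)c(O)c1C`: 9%

Among the compounds with values here, in an ADME assay (liver) for metabolic stability, with Liver microsome (Rattus norvegicus) as the target, read by LC-MS, using microsomes and NADPH, with stated times of 5 min and 60 min, tested at 4 uM (a lower number here means that less of the compound is left, a higher number that more of the compound is left), compound 1 gives 35%, the higher of the two numbers so far. Within the data shown here, compound 2 gives 9%, a gap beyond the scatter, but no single-point step between the two is available, so the two values stand on their own.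

Compound 3 `Cc1c(OCCCCOc2ccc(F)c(C(=O)O)c2)ccc(C(=O)CC(C)C)c1O` is the next point. Relative to compound 1 the change is isopropyl in place of methyl on a saturated chain carbon bound to a carbonyl carbon. The rest of compound 1 is kept. Among the measured compounds shown here, no measured pair shows this change. The only pointer is that the compound with another substituent at the carbonyl, compound 2, sits at 9%. On that basis a downward step is expected, probably beyond the scatter: a number 17 percentage points lower from compound 1 to compound 3 (beyond the scatter). Compound 3 is therefore estimated at 18%, with a range from 6% to 32%.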

Compound 3, percent of the compound remaining: 59%
Compound 3: middle estimate off by 41 percentage points, on the low side; measured number outside the range, above it.
By their numbers in this assay, from the lowest: compound 2; then compound 1; then compound 3.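

In this assay, within the data shown here, isopropyl in place of methyl on a saturated chain carbon bound to a carbonyl carbon gives the first single-place step: a number 24 percentage points higher from compound 1 to compound 3 (beyond the scatter). The group at this place therefore matters for the read-out, and on the core of compound 1 the larger, branched isopropyl goes with more of the compound left, which holds for this one pair only. No available data explain the step.

On these data alone, whether the trend continues with a tert-butyl group or a longer chain at this carbon remains open, as does the outcome with an amine or a hydroxyl group there. A single pair also cannot show whether the same change gives a step of similar size on another core.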